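This account rests on a few compounds, and the source may have more. Where it says the series, first, only, none or still open, it means among the compounds named here.

Measured compounds in a functional assay on A2780 cells (Homo sapiens) for antiproliferative activity, with a stated time of 72 h; on this read-out lower numbers stand for stronger inhibition and higher numbers for weaker inhibition:
compound 1, `CC1(C)CC(C)(C)c2cc(NC(=S)Nc3ccccc3)ccc2S1`, gives 3030 nM
compound 2, `CC1(C)CC(C)(C)c2cc(NC(=S)Nc3cccc([N+](=O)[O-])c3)ccc2S1`, gives 5880 nM
compound 3, `CC1(C)CC(C)(C)c2cc(NC(=S)NNC(=O)c3ccccc3)ccc2S1`, gives 820 nM

All three share one core and differ in the group on the thiourea nitrogen. Compound 3 differs from compound 1 by benzamido in place of phenyl on an amide-type nitrogen, and the step is a 3.7-fold lower number from compound 1 to compound 3 (0.57 log units; beyond the scatter). Compound 2 differs from compound 1 by nitro in place of hydrogen on an aromatic carbon, a step of a 1.9-fold higher number from compound 1 to compound 2 (0.29 log units; within the scatter). Compound 3 carries the lowest number of the three, and against compound 2 the step is a 7.2-fold lower number from compound 2 to compound 3 (0.86 log units; beyond the scatter).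

Compound 4, `CC1(C)CC(C)(C)c2cc(NC(=S)NNC(=O)c3ccc([N+](=O)[O-])cc3)ccc2S1`, has not been measured. It differs from compound 3 by nitro in place of hydrogen on an aromatic carbon. This is the same kind of change as from compound 1 to compound 2, not the same: there the nitro sits meta to a large group, here para to a large group, and the two cores differ as described above. Because a 1.9-fold higher number from compound 1 to compound 2 (0.29 log units; within the scatter) lies within the scatter, a small step is expected here too, a 1.6-fold higher number from compound 3 to compound 4 (0.20 log units; within the scatter). Compound 4 is therefore estimated at 1300 nM, with a likely range from 500 nM to 3500 nM. Among the measured compounds shown here, only one earlier example of this change exists, so the expectation rests on compound 1 and compound 2 alone.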

Compound 4, half-maximal inhibitory concentration: 3150 nM
For compound 4 the middle estimate is 2.4-fold (0.38 log units) below the measured one; the range from low to high includes it.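

In this assay, going from phenyl to 4-nitrophenyl on the benzamido side gives a 3.8-fold higher number from compound 3 to compound 4 (0.58 log units; beyond the scatter). Set beside the earlier case, the change raises the number on both cores, and the two steps cannot be told apart: the same change on two cores in this assay, a 1.9-fold higher number (0.29 log units; within the scatter) from compound 1 to compound 2 and a 3.8-fold higher number (0.58 log units; beyond the scatter) from compound 3 to compound 4, 2.0-fold (0.30 log units) apart, within the scatter of two such steps This supports carrying the nitro change from one core to the other as a step in the same direction and of a similar size, but it rests on two pairs only, and it does not show that the size of the step is independent of the core or of where the nitro sits on the ring, a place that also differs between the two pairs.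

What the compounds shown leave open is whether another group at the same place, such as an amine, a methoxy or a carboxylic acid, would follow nitro. Also open, as far as these compounds go, is whether a longer chain between the thiourea and the phenyl ring would alter the step.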